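A few compounds are considered here, and "the series" means these few. Any claim that something is new, unique, unknown or untested is made for them only; others in the source may bear on it.

Measured so far:
compound 1, `COc1cc(-c2nn(-c3cccc(NC(=O)Nc4cc(C(F)(F)F)cc(C(F)(F)F)c4)c3)cc2-c2ccncc2)ccc1Cl` — 1520 nM
compound 2, `O=C(Nc1cccc(-n2cc(-c3ccncc3)c(-c3ccc(Cl)c(O)c3)n2)c1)Nc1ccc(Cl)c(Cl)c1` — 3570 nM

In a functional assay on LOX IMVI cells (Homo sapiens) for inhibition, read by sulforhodamine B assay, with a stated time of 48 h (a lower number here means a stronger inhibitor of growth, a higher number a weaker inhibitor of growth), compound 1 gives 1520 nM, the lower of the two numbers; compound 2 gives 3570 nM, a gap beyond the usual scatter. Among the measured compounds shown here, no step between measured compounds that differ in a single place is known here. Compound 3, `COc1cc(-c2nn(-c3cccc(NC(=O)Nc4cccc(C(F)(F)F)c4)c3)cc2-c2ccncc2)ccc1Cl`, differs from compound 1 by hydrogen in place of trifluoromethyl on an aromatic carbon. With no shown step to lean on, a modest weakening, or none beyond the scatter, is expected: the step of a 1.6-fold higher number from compound 1 to compound 3 (0.22 log units; within the scatter) is the estimate. Compound 3 is expected to give about 2500 nM, within 1000 nM to 6500 nM.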

Compound 3, concentration for total growth inhibition: 1650 nM
Compound 3: the middle estimate sits 1.5-fold (0.18 log units) above what was measured; the range from low to high includes it.
By their numbers in this assay, from the lowest: compounds 1 and 3 (each within the scatter of the next); then compound 2.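

In this assay the step of a 1.1-fold higher number from compound 1 to compound 3 (0.04 log units; within the scatter) stays within the scatter, so hydrogen can stand in place of one trifluoromethyl on this aromatic carbon without a readable change. At this place, meta to a trifluoromethyl group, the second trifluoromethyl is thus not needed for the growth inhibition seen in compound 1. Nothing available explains this result. The compounds shown leave open whether an amine, a carboxylic acid or a nitrile at this place would shift the number, and whether the remaining trifluoromethyl could also give way to hydrogen.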